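From diethylamino to dimethylamino on the chloro compound

This account rests on a few compounds, and the source may have more. Where it says the series, first, only, none or still open, it means among the compounds named here.

Compound 1 `CCN(CC)Cc1cccc2c(=O)cc(-c3ccc([N+](=O)[O-])cc3)oc12` gives 28800 nM in a functional assay on HepG2 cells (Homo sapiens) for cytotoxicity, read by MTT assay, with a stated time of 48 h (a lower number here means a stronger inhibitor, a higher number a weaker inhibitor), as its value
Compound 2 `CCN(CC)Cc1cc(Cl)cc2c(=O)cc(-c3ccc([N+](=O)[O-])cc3)oc12` gives 1190 nM in this assay as its value
Compound 3 `CN(C)Cc1cc(Cl)cc2c(=O)cc(-c3ccc([N+](=O)[O-])cc3)oc12` is not yet measured

Among the measured compounds shown here, compound 2 at 1190 nM holds the lowest of the two numbers so far. Compound 3 carries one change, dimethylamino in place of diethylamino on a saturated chain carbon bound to an aromatic carbon on a saturated chain carbon bound to an aromatic carbon. For the measured compounds named here, the only measured step, a 24-fold lower number from compound 1 to compound 2 (1.38 log units; beyond the scatter), was large, but it was chloro in place of hydrogen on an aromatic carbon and does not touch the amine. Going by the values given here, no measured step covers this change, so no shift beyond the scatter is expected in this assay for now. The expected step is a 1.3-fold higher number from compound 2 to compound 3 (0.10 log units; within the scatter) and it stays modest. Compound 3 is estimated at 1500 nM within an expected range of 550 nM to 4500 nM as its likely reading.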

Compound 3, half-maximal inhibitory concentration: 6190 nM
Compound 3: the middle estimate sits 4.1-fold (0.62 log units) below what was measured; measured number above the stated range.
By their numbers in this assay, from the lowest: compound 2; then compound 3; then compound 1.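

In this assay, the amine on the saturated chain carbon bound to an aromatic carbon turns out to matter: dimethylamino in place of diethylamino gives a 5.2-fold higher number from compound 2 to compound 3 (0.72 log units; beyond the scatter) and so lies beyond the scatter. Among the compounds shown here, the earlier step changed only the chloro, so this is the first reading of the amine, and with the chloro in place diethylamino holds the lower number. No measurement shown here explains this step.

Going by these compounds, it remains open whether a ring amine such as piperidine or morpholine, or a longer chain such as dipropylamino, would go lower than compound 2. On these data alone, it is also open whether the same amine change gives a similar step on compound 1, which has hydrogen in place of the chloro.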